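Cytotoxicity on the shared core: from compound 3 to compound 4

The compounds below may be only part of what the source reports. "The series", "measured", "known", "first", "only" and "open" are said of these compounds alone.

Measured so far:
compound 1 `CC(O)c1cccc(C(=O)N[C@@H](C)Cn2ccc(-c3ccc(C#N)c(Cl)c3)n2)c1` — > 30000 nM
compound 2 `CC(Cn1ccc(-c2ccc(C#N)c(Cl)c2)n1)C(=O)Nc1cccc(C(C)O)c1` — > 30000 nM
compound 3 `C[C@@H](Cn1ccc(-c2ccc(C#N)c(Cl)c2)n1)NS(=O)(=O)c1cccnc1` — > 30000 nM

In an ADME assay on PC-3 cells (Homo sapiens) for cytotoxicity, read by CCK-8 assay, with a stated time of 6 days (a higher number here means a weaker inhibitor, a lower number a stronger inhibitor), compound 1 gives only a limit of the assay, > 30000 nM. Compound 2 also gives only a limit, > 30000 nM. Compound 3 likewise gives only a limit in this assay, > 30000 nM. Compound 3 therefore cannot be placed above or below the other two: all three values coincide with the limit of > 30000 nM in this assay, at which 3 of the 3 values shown sit, and no numbered value exists for any of them. Among the measured compounds shown here, no step between measured compounds can be given.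

Compound 4 `C[C@@H](Cn1ccc(-c2ccc(C#N)c(Cl)c2)n1)Nc1nccc(Cl)n1` is not yet measured in this assay. It differs from compound 3 by 4-chloropyrimidin-2-yl in place of (pyridin-3-yl)sulfonyl on an amine nitrogen. Nothing in the measured set shows what such a change does here, since every value is a limit. With compound 3 at > 30000 nM, the step of a number no higher from compound 3 to compound 4 (the limit leaves the size open) is expected to be none beyond the scatter, in no particular direction. Compound 4 is thus expected to give about 30000 nM in this assay, within 10000 nM to 100000 nM, most likely again reported only as a limit.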

Compound 4, half-maximal inhibitory concentration: > 30000 nM
Compound 4: only a limit was reported; the forecaster's own chance of this, stated with the estimate: 80%; the middle value lies on the limit itself.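

In this assay compound 4 gives > 30000 nM as a limit of the assay. Among the compounds shown here, compound 3 gives > 30000 nM as a limit too, so no step between compound 3 and compound 4 can be read. The compounds shown leave open whether any change on the shared core affects cytotoxicity in these cells.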